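The source may hold more compounds than are shown below. What is called first, only, known or untested is meant among the compounds shown, and "the series" means these compounds.

Of the compounds shown here, three of a shared core have been tested in a functional assay on MGC-803 cells (Homo sapiens) for inhibition, read by MTT assay, with a stated time of 48 h; on this read-out higher numbers stand for weaker inhibition and lower numbers for stronger inhibition. Compound 1 `CCC(=O)N(Cc1ccc(OC)c(O)c1)c1cc(OC)c(OC)c(OC)c1` gives 50 nM. Compound 2 `COc1ccc(CN(C(=O)CCCl)c2cc(OC)c(OC)c(OC)c2)cc1O` gives 140 nM. Compound 3 `COc1ccc(CN(C(C)=O)c2cc(OC)c(OC)c(OC)c2)cc1O` gives 79 nM. On these numbers compound 3 stands between the other two, and its gaps to both are within the scatter: a 1.6-fold higher number from compound 1 to compound 3 (0.20 log units; within the scatter) and a 1.8-fold lower number from compound 2 to compound 3 (0.25 log units; within the scatter). All three carry the same core and differ only in the chain on the amide carbonyl.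

Compound 4 `COc1ccc(CN(C(=O)CCCCCl)c2cc(OC)c(OC)c(OC)c2)cc1O` extends that chain further. Its difference from compound 3 is 3-chloropropyl in place of hydrogen on a saturated chain carbon bound to a carbonyl carbon. Within the data shown here, the steps that bear on this are the chain changes already seen: lengthening the chain gave a 1.6-fold higher number from compound 1 to compound 3 (0.20 log units; within the scatter), and placing a chlorine on it gave a 2.8-fold higher number from compound 1 to compound 2 (0.45 log units; beyond the scatter), the only step here that reaches beyond the scatter. Compound 4 combines a longer chain with a chlorine at its end, so a step toward weaker inhibition of roughly the size seen with compound 2 seems the most likely outcome, while a result within the scatter of compound 3 cannot be ruled out.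

Compound 4 is therefore expected to give 150 nM, in the range 60 nM to 400 nM, which means an estimated step of a 1.9-fold higher number from compound 3 to compound 4 (0.28 log units; within the scatter).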

Compound 4, half-maximal inhibitory concentration: 540 nM
Compound 4: middle estimate off by 3.6-fold (0.56 log units), on the low side; measured number above the stated range.
By their numbers in this assay, from the lowest: compounds 1, 3 and 2 (each within the scatter of the next, the first and the last beyond it); then compound 4.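

This result shows that the position is not indifferent to what the chain carries: in this assay, placing 3-chloropropyl on the saturated chain carbon bound to a carbonyl carbon gives a 6.8-fold higher number from compound 3 to compound 4 (0.83 log units; beyond the scatter), well beyond the scatter. The longer chlorine-bearing chain also does clearly worse than the shorter one, with a 3.9-fold higher number from compound 2 to compound 4 (0.59 log units; beyond the scatter), and the gap to the propionyl-type chain widens to an 11-fold higher number from compound 1 to compound 4 (1.03 log units; beyond the scatter), which leaves compound 4 as the weakest inhibitor of the four, although only two chlorine-bearing chains support this trend. Nothing available here explains why the longer chain has this effect.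

The compounds shown leave open whether the length of the chain or the chlorine at its end accounts for the loss, a question that a plain butyl chain in place of 4-chlorobutyl would help settle. They also leave open whether an amine or a hydroxyl group at the end of the same chain would behave like the chlorine.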